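This account rests on a few compounds, and the source may have more. Where it says the series, first, only, none or still open, it means among the compounds named here.

Compound 1 `CC(C)C[C@H](N)CN(C(=O)[C@@H]1C[C@H]1c1ccccc1)c1ccc(-c2ccc(F)cc2)cc1`: 900 nM
Compound 2 `CC(C)C[C@H](N)CN(C(=O)[C@@H]1C[C@H]1c1ccccc1)c1ccc(-c2cccc(F)c2)cc1`: 2100 nM

In a functional assay for agonist activity at G protein-coupled receptor 88 (Homo sapiens), read by HTRF and cAMP accumulation (on this read-out lower numbers stand for an effect already at smaller amounts and higher numbers for an effect only at larger amounts of compound), compound 2 stands at the higher of the two numbers; the step of a 2.3-fold higher number from compound 1 to compound 2 (0.37 log units; beyond the scatter) is modest yet beyond the scatter. Compound 3 `CC(C)C[C@H](N)CN(C(=O)[C@@H]1C[C@H]1c1ccccc1)c1ccc(-c2cccc(C#N)c2)cc1` differs from compound 2 by cyano in place of fluoro on an aromatic carbon. For the measured compounds named here, no measured step exchanges these two groups for each other, and the single known step only moves the fluoro, so the direction of this change is open. A level close to compound 2 is therefore expected for compound 3, with a step of a 1.1-fold lower number from compound 2 to compound 3 (0.02 log units; within the scatter) that may stay within the scatter, and its value is estimated at 2000 nM, ranging from 700 nM to 6000 nM.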

Compound 3, half-maximal effective concentration: 4500 nM
Beside the measured number, compound 3's estimate is 2.3-fold (0.35 log units) below it; the range from low to high includes it.
By their numbers in this assay, from the lowest: compound 1; then compound 2; then compound 3.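

In this assay, on an aromatic carbon meta to a large group, cyano does not hold the level of fluoro: the exchange gives a 2.1-fold higher number from compound 2 to compound 3 (0.33 log units; beyond the scatter) and is modest but beyond the scatter. This position therefore responds to which group sits there, not only to where a fluoro is placed, and a 5.0-fold higher number from compound 1 to compound 3 (0.70 log units; beyond the scatter) is the largest step among these compounds. Nothing available explains this shift.

Still open, from the compounds shown here alone, is how an amine or a methoxy group would fare at this place, and whether any group there can match compound 1.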